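This account rests on a few compounds, and the source may have more. Where it says the series, first, only, none or still open, it means among the compounds named here.

Compound 2 `N#Cc1ccc(-c2csc(N3N=C(c4ccc(Cl)s4)CC3c3ccc(F)cc3)n2)cc1` was tested in an ADME assay on NIH3T3 cells (Mus musculus) for cytotoxicity, read by XTT assay, with a stated time of 24 h; a higher number here means a weaker inhibitor, a lower number a stronger inhibitor. In this assay compound 2 gives > 500 ug/mL, which is a limit of the assay rather than a number. Compound 1 `Cc1ccc(C2=NN(c3nc(-c4ccc(Br)cc4)cs3)C(c3ccc(F)cc3)C2)s1` rests at the same limit: in this assay compound 1 gives > 500 ug/mL. Compound 3 `Cc1ccc(C2=NN(c3nc(-c4ccc(C#N)cc4)cs3)C(c3ccc(F)cc3)C2)s1` differs from compound 2 by methyl in place of chloro on an aromatic carbon. No measured pair covers such a change, yet both shown values sit at the limit (the limit of > 500 ug/mL in this assay, at which 2 of the 2 values shown sit), so no step beyond the scatter is expected here. The step from compound 2 to compound 3 is expected to be about none a number no higher from compound 2 to compound 3 (the limit leaves the size open). Compound 3 is thus estimated at 500 ug/mL, within 250 ug/mL to 1000 ug/mL.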

Compound 3, half-maximal inhibitory concentration: 250 ug/mL
For compound 3 the middle estimate is 2.0-fold (0.30 log units) above the measured one; low and high end bracket the measured number.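

In this assay, among these compounds, compound 3 gives 250 ug/mL, the only value shown that is a number rather than a limit. Going from 5-chlorothiophen-2-yl to 5-methylthiophen-2-yl gives an at least 2.0-fold lower number from compound 2 to compound 3 (0.30 log units; that floor lies within the scatter), while cyano in place of bromo gives an at least 2.0-fold lower number from compound 1 to compound 3 (0.30 log units; that floor lies within the scatter). Neither floor goes beyond the scatter, and the true size of each step stays unknown because the other two compounds rest at a limit: the limit of > 500 ug/mL in this assay, at which 2 of the 3 values shown sit.

The compounds shown leave open whether methyl or cyano alone can lower the number. They also leave open how an amine or a carboxylic acid would behave on that aromatic carbon.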